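The source may report more compounds than this note shows. Statements on the series, on what has been measured and on what is new or still open speak of the compounds shown alone.

Working notes on the series. All compounds share one core, seen in compound 1 `N#Cc1ccc(Nc2nc(Oc3ccnc4ccccc34)nc(N3CCCCC3)n2)cc1C(F)(F)F`, compound 2 `N#Cc1ccc(Nc2nc(Oc3ccnc4ccccc34)nc(N3CCN(c4ccccn4)CC3)n2)cc1C(F)(F)F` and compound 3 `N#Cc1ccc(Nc2nc(Oc3ccnc4ccccc34)nc(N3CCN(C(c4ccccc4)c4ccc(Cl)cc4)CC3)n2)cc1C(F)(F)F`; they differ only in the amine attached to it. In a functional assay on DU-145 cells (Homo sapiens) for cytotoxicity, read by sulforhodamine B assay, with a stated time of 48 h (on this read-out lower numbers stand for stronger inhibition of growth and higher numbers for weaker inhibition of growth), compound 1 gives 94900 nM. In this assay compound 2 gives 85900 nM. Compound 3 returns only a limit in this assay, namely > 100000 nM. For the measured compounds named here, the single counted step, a 1.1-fold lower number from compound 1 to compound 2 (0.04 log units; within the scatter), is within the scatter, so compound 2 and compound 1 stand within the scatter of each other, and the remaining value sits at the limit of > 100000 nM in this assay, at which 1 of the 3 values shown sits.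

Compound 4 `N#Cc1ccc(Nc2nc(Oc3ccnc4ccccc34)nc(N3CCN(c4cccc(Cl)c4Cl)CC3)n2)cc1C(F)(F)F` carries the change (2,3-dichlorophenyl in place of pyridin-2-yl on an amine nitrogen in a ring). Going by the values given here, no measured step exchanges the group on this ring nitrogen for one of this kind; the only step that touches the same end of the molecule, a 1.1-fold lower number from compound 1 to compound 2 (0.04 log units; within the scatter), was within the scatter, and compound 3, which carries the largest group there, gave a limit rather than a number. The expectation is therefore a number close to that of compound 2, with a real chance of a limit. Compound 4 is expected at 90000 nM, between 40000 nM and 200000 nM. The step of a 1.0-fold higher number from compound 2 to compound 4 (0.02 log units; within the scatter) is expected to stay within the scatter.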

Compound 4, concentration for 50% growth inhibition: > 100000 nM
Compound 4: only a limit was reported (the forecaster's own chance of this, stated with the estimate: 40%); middle value at least 1.1-fold (0.04 log units) away from the limit.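

The change to 2,3-dichlorophenyl in place of pyridin-2-yl on the amine nitrogen in the ring gives an at least 1.1-fold higher number from compound 2 to compound 4 (0.06 log units; that floor lies within the scatter), and this is only a floor, so the true size of the step is not known and the two compounds cannot be separated. In this assay compound 4 returns > 100000 nM, which is a limit of the assay and not a number. With this result, compound 3 and compound 4 both end at the limit while compound 2 still gives a number, so a second, different group on this ring nitrogen now leaves the read-out without a measurable value: the limit of > 100000 nM in this assay, at which 2 of the 4 values shown sit.

As far as these compounds go, it remains open whether any group on this ring nitrogen can move the number in this assay beyond the scatter, as compound 1 and compound 2 stand within the scatter of each other and the other two compounds give only limits. Also open, from the compounds shown here alone, is how a group of another kind at this position, such as a carboxylic acid on a short chain or a primary amine on a longer chain, would read in the same assay.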